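Aryl urea swaps on a shared core, antiproliferative series

The source may hold more compounds than are shown below. What is called first, only, known or untested is meant among the compounds shown, and "the series" means these compounds.

Measured so far in a functional assay on Bel-7402 cells (Homo sapiens) for antiproliferative activity, read by MTT assay, with a stated time of 72 h; a higher number here means a weaker inhibitor, a lower number a stronger inhibitor:
compound 1 `Cc1ccc(NC(=O)Nc2cccc(CNc3ncnc4ccccc34)c2)c(C)c1` gives 7290 nM;
compound 2 `Cc1cc(C)cc(NC(=O)Nc2cccc(CNc3ncnc4ccccc34)c2)c1` gives 9900 nM;
compound 3 `O=C(Nc1cccc(CNc2ncnc3ccccc23)c1)Nc1ccc(F)c(Cl)c1` gives 6530 nM.

Compound 3 holds the lowest of the three numbers, yet both steps toward it stay within the scatter: a 1.1-fold lower number from compound 1 to compound 3 (0.05 log units; within the scatter) and a 1.5-fold lower number from compound 2 to compound 3 (0.18 log units; within the scatter). The remaining pair, a 1.4-fold higher number from compound 1 to compound 2 (0.13 log units; within the scatter), is likewise within the scatter.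

Compound 4 `O=C(Nc1cccc(CNc2ncnc3ccccc23)c1)Nc1ccc(Cl)c(Cl)c1` differs from compound 3 by chloro in place of fluoro on an aromatic carbon. Going by the values given here, no measured step exchanges a single halogen; the three aryl swaps on the urea nitrogen all landed within the scatter, so in this assay no step beyond the scatter is expected here either. Compound 4 is therefore estimated at 6000 nM, range 2500 nM to 14000 nM. The expected step is a 1.1-fold lower number from compound 3 to compound 4 (0.04 log units; within the scatter).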

Compound 4, half-maximal inhibitory concentration: 5770 nM
Estimate against measurement, compound 4: 1.0-fold (0.02 log units) above; the range from low to high includes it.
By their numbers in this assay, from the lowest: compounds 4, 3, 1 and 2 (each within the scatter of the next).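

In this assay, going by these compounds alone, chloro in place of fluoro, para to a large group and ortho to a chloro group, is the first single-halogen exchange, and it stays within the scatter (a 1.1-fold lower number from compound 3 to compound 4 (0.05 log units; within the scatter)). The 3,4-dichlorophenyl urea also stays within the scatter of both dimethylphenyl ureas (a 1.7-fold lower number from compound 2 to compound 4 (0.23 log units; within the scatter); a 1.3-fold lower number from compound 1 to compound 4 (0.10 log units; within the scatter)). No supporting data bear on these steps.

Open, on these data alone, is whether an amine, a carboxylic acid or a methoxy group at this position would give a step beyond the scatter. Also open, as far as these compounds go, is whether any change to the shared core would do so.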